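This account rests on a few compounds, and the source may have more. Where it says the series, first, only, none or still open, it means among the compounds named here.

Measured in a functional assay on MV4-11 cells (Homo sapiens) for antiproliferative activity, read by CellTiter-Glo, with a stated time of 72 h; on this read-out lower numbers stand for stronger inhibition of growth and higher numbers for weaker inhibition of growth:
Compound 1 `N[C@H]1CC[C@H](Nc2cc(-c3csc(NCC4CCOCC4)n3)c(Cl)cn2)CC1`: 140 nM
Compound 2 `COCC(=O)N[C@H]1CC[C@H](Nc2cc(-c3csc(NCC4CCOCC4)n3)c(Cl)cn2)CC1`: > 10000 nM

In this assay compound 2 reads > 10000 nM, which is a limit of the assay and not a number. Compound 3 `COCCN[C@H]1CC[C@H](Nc2cc(-c3csc(NCC4CCOCC4)n3)c(Cl)cn2)CC1` carries 2-methoxyethyl in place of (methoxymethyl)carbonyl on an amine nitrogen, (2-methoxyethyl in place of (methoxymethyl)carbonyl on an amine nitrogen). Among the compounds with values here, one measured step bears on this change: an at least 71-fold higher number from compound 1 to compound 2 (1.85 log units; beyond the scatter), a large step that came with putting (methoxymethyl)carbonyl on that nitrogen in place of hydrogen. Compound 3 no longer has that group, so much of this step is expected to be reversed. Within the data shown here, no measured step shows how 2-methoxyethyl itself behaves there, so the expectation stays loose, and compound 1 at 140 nM serves as the nearest reference. A large step towards a lower number is expected, an at least 33-fold lower number from compound 2 to compound 3 (1.52 log units; beyond the scatter). For compound 3 the estimate is 300 nM, with an expected range of 70 nM to 1500 nM.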

Compound 3, concentration for 50% growth inhibition: 170 nM
The estimate for compound 3 lay 1.8-fold (0.25 log units) above the measured number; measured number inside the range.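

In this assay, 2-methoxyethyl in place of (methoxymethyl)carbonyl on the amine nitrogen gives an at least 58-fold lower number from compound 2 to compound 3 (1.76 log units; beyond the scatter). Compound 2 stands at a limit of the assay and not at a number: the limit of > 10000 nM in this assay, at which 1 of the 3 values shown sits. Against the free amine, 2-methoxyethyl gives a 1.2-fold higher number from compound 1 to compound 3 (0.08 log units; within the scatter), so in this pair the nitrogen carries a chain with no step beyond the scatter, and the large step seen earlier goes with (methoxymethyl)carbonyl and not with every substituent on that nitrogen.

As far as these compounds go, whether other groups on this nitrogen, such as a longer ether chain or a carboxylic acid, behave like 2-methoxyethyl stays open. Also open, from the compounds shown here alone, is which part of (methoxymethyl)carbonyl goes with the large step, a question that an acetyl group or a plain ethyl chain there would bear on.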